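Moving the Fluorine Around the Ring: Compound 3 to Compound 4

The source may hold more compounds than are shown below. What is called first, only, known or untested is meant among the compounds shown, and "the series" means these compounds.

The measured compounds, in a functional assay on the whole organism (strain Albino Swiss CD1) with Mus musculus as the target (on this read-out higher numbers stand for an effect only at larger amounts of compound and lower numbers for an effect already at smaller amounts), are:
compound 1, `CCC(C(=O)NCc1ccccc1)N1C(=O)CCC1=O`, with 90.3 mg/kg;
compound 2, `CCC(C(=O)NCc1ccc(Cl)cc1)N1C(=O)CCC1=O`, with 50.8 mg/kg;
compound 3, `CCC(C(=O)NCc1ccccc1F)N1C(=O)CCC1=O`, with 65.7 mg/kg.

All three share one core and differ only in the aromatic ring attached to the amide-type nitrogen through a saturated chain carbon. Compound 3 sits between the other two on the numbers, and neither gap reaches beyond the scatter: there is a 1.4-fold lower number from compound 1 to compound 3 (0.14 log units; within the scatter) and a 1.3-fold higher number from compound 2 to compound 3 (0.11 log units; within the scatter).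

Compound 4, `CCC(C(=O)NCc1ccc(F)cc1)N1C(=O)CCC1=O`, has not yet been measured. It differs from compound 3 by 4-fluorophenyl in place of 2-fluorophenyl on a saturated chain carbon bound to an amide-type nitrogen; the same atoms are simply joined differently. Among the measured compounds shown here, three measured steps bear on this. Putting chloro onto the ring gave a 1.8-fold lower number from compound 1 to compound 2 (0.25 log units; within the scatter), putting fluoro onto it gave a 1.4-fold lower number from compound 1 to compound 3 (0.14 log units; within the scatter), and swapping a 4-chlorophenyl for a 2-fluorophenyl gave a 1.3-fold higher number from compound 2 to compound 3 (0.11 log units; within the scatter). Each of these lies within the scatter, so a halogen on this ring, wherever the data have placed it, has not shifted this assay beyond noise. The expected step is therefore a 1.1-fold lower number from compound 3 to compound 4 (0.05 log units; within the scatter), no real shift in either direction. Compound 4 is estimated at 58 mg/kg, with a range from 32 mg/kg to 105 mg/kg.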

Compound 4, dose for half-maximal effect: 83.4 mg/kg
The estimate for compound 4 lay 1.4-fold (0.16 log units) below the measured number, within the range that was stated.
By their numbers in this assay, from the lowest: compounds 2, 3, 4 and 1 (each within the scatter of the next).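

Moving the fluorine, with 4-fluorophenyl in place of 2-fluorophenyl, gives a change that stays within the scatter (a 1.3-fold higher number from compound 3 to compound 4 (0.10 log units; within the scatter)), so in this assay these two placings on the ring cannot be told apart. Compound 4 also stays within the scatter of the compounds carrying chloro (a 1.6-fold higher number from compound 2 to compound 4 (0.22 log units; within the scatter)) and hydrogen (a 1.1-fold lower number from compound 1 to compound 4 (0.03 log units; within the scatter)), so every printed step among the four compounds now lies within the scatter, and none of these ring changes shows a real effect. No measurement shown here offers an explanation for how alike these compounds read.

Still open, from the compounds shown here alone, is whether a different ring group, such as a nitrile, a methoxy group or an amine, would move the number beyond the scatter. Also open, going by these compounds, is what a longer chain would do in place of the saturated chain carbon bound to the amide-type nitrogen.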